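Swapping the ethyl for an aryl group on the ring nitrogen

The compounds below may be only part of what the source reports. "The series", "measured", "known", "first", "only" and "open" are said of these compounds alone.

Compound 1 `CCN1C(=O)CSC1c1cccc(C(=O)NCCCCc2ccccc2)c1` sits at the limit of the assay rather than a number: in a functional assay on HOS-TE85 cells (Homo sapiens) for inhibition, read by CCK-8 assay, with a stated time of 72 h (on this read-out higher numbers stand for weaker inhibition and lower numbers for stronger inhibition), compound 1 gives > 1000 nM. Compound 2 `O=C(NCCCc1ccccc1)c1cccc(C2SCC(=O)N2c2ccc(C3CC3)cc2)c1` also reports a limit, giving > 1000 nM in this assay. Both values therefore rest on the same line: the limit of > 1000 nM in this assay, at which 2 of the 2 values shown sit. Compound 3 `O=C(NCCCCc1ccccc1)c1cccc(C2SCC(=O)N2c2ccccc2F)c1` differs from compound 1 by 2-fluorophenyl in place of ethyl on an amide-type nitrogen in a ring. Since compound 2 already carries an aryl group on that nitrogen and stays at the limit, the step is expected to be small, a step that the limit leaves unreadable from compound 1 to compound 3, with no direction beyond the scatter. Compound 3 is estimated at 2000 nM, between 600 nM and 8000 nM.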

Compound 3, half-maximal inhibitory concentration: 34.1 nM
For compound 3 the middle estimate is 59-fold (1.77 log units) above the measured one; the measured number lies below the stated range.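

In this assay, 2-fluorophenyl in place of ethyl on the amide-type nitrogen in the ring gives an at least 29-fold lower number from compound 1 to compound 3 (1.46 log units; beyond the scatter), which shows that this position is not indifferent to the group it carries. For the compounds shown here, the size of the step is a bound and not an exact figure, since compound 1 stands at a limit: the limit of > 1000 nM in this assay, at which 2 of the 3 values shown sit. Compound 2 differs from compound 3 in more than one place, so no step between them can be read.

The compounds shown leave open whether the phenyl ring or its fluorine carries the step, which a plain phenyl or a 2-chlorophenyl on that nitrogen would help separate. On these data alone, how a pyridyl group would fare there also remains open.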